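The source may hold more compounds than are shown below. What is called first, only, known or untested is meant among the compounds shown, and "the series" means these compounds.

Measured so far in a functional assay on NCI-H460 cells (Homo sapiens) for antiproliferative activity, read by MTT assay, with a stated time of 48 h; on this read-out higher numbers stand for weaker inhibition and lower numbers for stronger inhibition:

Compound 1, `O=C(CSc1nnc(NC(=O)CCl)s1)Nc1ccc(Cl)cn1`, gives 5700 nM.
Compound 2, `O=C(CSc1nnc(NC(=O)CCl)s1)Nc1ccc(Br)cn1`, gives 7500 nM.
Compound 3, `O=C(CCl)Nc1ccc(SCC(=O)Nc2ccc(Cl)cn2)cc1`, gives 420 nM.

Compound 1 and compound 2 share one core and differ in a single place: bromo in place of chloro on an aromatic carbon. That change produced a 1.3-fold higher number from compound 1 to compound 2 (0.12 log units; within the scatter), so the two numbers cannot be told apart with confidence. Compound 3 is built on a different core, and the difference between its core and the core of compound 1 is not broken down here. What the numbers show is that compound 3 gives the lowest value of the three, and that its gap to compound 1 and to compound 2 lies well beyond the usual scatter, so compound 3 is the strongest inhibitor among the measured compounds.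

Compound 4, `O=C(CCl)Nc1ccc(SCC(=O)Nc2ccc(Br)cn2)cc1`, has not yet been measured. Within the data shown here, it differs from compound 3 by bromo in place of chloro on an aromatic carbon, which is the same change, at the same place, as the one from compound 1 to compound 2. Because that earlier change gave only a 1.3-fold higher number from compound 1 to compound 2 (0.12 log units; within the scatter), the expectation is that compound 4 will stay close to compound 3, with an estimated step of a 1.2-fold higher number from compound 3 to compound 4 (0.09 log units; within the scatter). The value expected for compound 4 in this assay is therefore 520 nM, with a likely range from 250 nM to 1100 nM.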

Compound 4, half-maximal inhibitory concentration: 530 nM
Estimate against measurement, compound 4: 1.0-fold (0.01 log units) below; the measured number falls inside the stated range.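

In this assay, replacing 5-chloropyridin-2-yl with 5-bromopyridin-2-yl on the second core gave a 1.3-fold higher number from compound 3 to compound 4 (0.10 log units; within the scatter), so the two numbers cannot be told apart with confidence. The same exchange on the first core was just as small, and the two steps themselves cannot be separated: the same change on two cores in this assay, a 1.3-fold higher number (0.12 log units; within the scatter) from compound 1 to compound 2 and a 1.3-fold higher number (0.10 log units; within the scatter) from compound 3 to compound 4, 1.0-fold (0.02 log units) apart, within the scatter of two such steps This shows that, for these two pairs, the exchange of chloro for bromo carries over from one core to the other, leaving the number within the usual scatter both times; it does not show that the two groups are interchangeable in general, since two pairs in a single cell assay cannot rule out a small real difference, cannot predict the result on a third core and cannot say why the step is so small.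

The compounds shown contain only chloro and bromo at this place on the ring, so it remains open what a quite different group there, such as a methyl, a methoxy, an amine or a carboxylic acid, would do to the number. From the compounds shown here alone, it also remains open whether such a group would give the same step on both cores, as the exchange of chloro for bromo does.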